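Compound 1 Without Its 2-Chlorobenzyl Group

This account rests on a few compounds, and the source may have more. Where it says the series, first, only, none or still open, it means among the compounds named here.

In a functional assay on A549 cells (Homo sapiens) for cytotoxicity, read by MTT assay, with a stated time of 72 h (a lower number here means a stronger inhibitor, a higher number a weaker inhibitor), compound 1 `CN(C)Cc1ccc2nc(NC(=O)N/N=C/c3cn(Cc4ccccc4Cl)c4ccccc34)sc2c1` gives 1080 nM as its number. Compound 3 `CCN(CC)Cc1ccc2nc(NC(=O)N/N=C/c3cn(Cc4ccc(C)cc4)c4ccccc34)sc2c1` gives 1510 nM as its number, which lies within the usual scatter of compound 1. Compound 2 `CCN(CC)Cc1ccc2nc(NC(=O)N/N=C/c3cn(Cc4cccc(Cl)c4)c4ccccc34)sc2c1` gives 2410 nM as its number, a higher one than compound 1 shows and beyond the scatter. Compound 1 therefore sits at the stronger end of this small set without standing clear of compound 3.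

Compound 4 `CN(C)Cc1ccc2nc(NC(=O)N/N=C/c3c[nH]c4ccccc34)sc2c1` has hydrogen in place of 2-chlorobenzyl on an aromatic nitrogen and is otherwise compound 1. Going by the values given here, the one measured step that comes near this place is a 1.6-fold lower number from compound 2 to compound 3 (0.20 log units; within the scatter) and it only swaps 3-chlorophenyl for 4-methylphenyl while the chain carbon stays on the aromatic nitrogen. Among the compounds with values here, that step says little about losing the whole group, and no compound without such a group has been measured, so the direction remains uncertain. Even so, the change is much larger than that swap, so a move to a higher number, beyond the scatter, is expected. The estimated step is a 3.2-fold higher number from compound 1 to compound 4 (0.51 log units; beyond the scatter) in this assay and it is only a rough expectation. For compound 4 the estimated value is 3500 nM with an expected range from 1200 nM to 12000 nM on this reasoning.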

Compound 4, half-maximal inhibitory concentration: 3300 nM
The estimate for compound 4 lay 1.1-fold (0.03 log units) above the measured number, and the stated range covers the measured number.
By their numbers in this assay, from the lowest: compounds 1, 3, 2 and 4 (each within the scatter of the next, the first and the last beyond it).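

Replacing the 2-chlorobenzyl group on the aromatic nitrogen with hydrogen gives a 3.1-fold higher number from compound 1 to compound 4 (0.49 log units; beyond the scatter) in this assay. Going by these compounds alone, compounds 1, 2 and 3 all carry a substituted benzyl group at this nitrogen, so they could compare only one such group with another; this step shows that having a group there at all makes a difference beyond the scatter, at least on the core of compound 1. The step is modest, however, and compound 4 still gives a measurable number without the group and its six-membered aromatic ring, so the 2-chlorobenzyl group accounts for only part of the activity of compound 1, and nothing available here explains the rise in the number.

Going by these compounds, it remains open whether a small methyl group, a longer chain such as butyl or an unsubstituted benzyl group at this nitrogen would bring the number back towards that of compound 1, which would help show whether the ring or the chlorine matters more. On these data alone, it is also open whether removing the group would produce a similar step in compounds with the amine side chain of compounds 2 and 3.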